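(2-Hydroxyethyl)amino gives way to piperazin-1-yl

This account rests on a few compounds, and the source may have more. Where it says the series, first, only, none or still open, it means among the compounds named here.

In a functional assay on HCT-116 cells (Homo sapiens) for cytotoxicity, read by MTT assay, with a stated time of 72 h (on this read-out higher numbers stand for weaker inhibition and lower numbers for stronger inhibition), compound 1 `Nc1cccc(Nc2c(C(=O)NCc3ccc(F)cc3)nc(Br)c3cccnc23)c1` gives > 10000 nM, which is a limit of the assay and not a number. Compound 2 `O=C(NCc1ccc(F)cc1)c1nc(Br)c2cccnc2c1NCCO` gives > 20000 nM, which is also a limit. Among the measured compounds shown here, compound 2 therefore has no exact number, and neither does the only other compound measured so far. Compound 3 `O=C(NCc1ccc(F)cc1)c1nc(Br)c2cccnc2c1N1CCNCC1` keeps the shared core and changes one group, with piperazin-1-yl in place of (2-hydroxyethyl)amino on an aromatic carbon, para to a bromo group: piperazin-1-yl in place of (2-hydroxyethyl)amino on an aromatic carbon. For the measured compounds named here, only one measured step can bear on this change, and it concerns a different swap. Since a step that the two limits leave unreadable from compound 1 to compound 2 has no readable size, it gives no firm basis for expecting a shift in either direction. The expected change is therefore none beyond the scatter, and the estimated step is a number no higher from compound 2 to compound 3 (the limit leaves the size open). For compound 3, the estimated value is 20000 nM, with an expected range from 7000 nM to 50000 nM.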

Compound 3, half-maximal inhibitory concentration: > 10000 nM
Compound 3 ended at the assay's limit; the forecaster's own chance of this, stated with the estimate: 70%; the middle value lies beyond the limit too.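

In this assay compound 3 gives > 10000 nM, which is a limit and not a number. Among the compounds shown here, compound 1 and compound 2 also stand at limits, so no step among the three can be read. The compounds shown leave open how strongly any of them inhibits, and whether swapping these groups changes that at all.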